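Mirror Image of Compound 3 in the Cell Toxicity Test

The source may report more compounds than this note shows. Statements on the series, on what has been measured and on what is new or still open speak of the compounds shown alone.

Within the data shown here, compound 3 `c1ccc([C@H](CCn2cncn2)C2CCCCC2)cc1` gives 11.8 ug/mL in an ADME assay on RD cells (Homo sapiens) for cytotoxicity, read by MTT assay, with a stated time of 3 days (on this read-out lower numbers stand for higher toxicity in this test and higher numbers for lower toxicity in this test), the lowest of the three numbers measured so far; compound 1 `c1ccc(C[C@H](CCn2cncn2)c2ccccc2)cc1` gives 55.4 ug/mL and compound 2 `c1ccc(C[C@@H](CCn2cncn2)c2ccccc2)cc1` gives 56 ug/mL. Compound 4 `c1ccc([C@@H](CCn2cncn2)C2CCCCC2)cc1` is the mirror image of compound 3: the two compounds have the same atoms and bonds and differ only in configuration as drawn: 1 of 1 stereo elements differ; a stereocentre at a saturated chain carbon is drawn R in compound 3 and S in compound 4. Among the measured compounds shown here, one measured step bears directly on this change. Compounds 1 and 2 are related in the same way (the fact that compounds 1 and 2 differ only in the configuration as drawn), and between them the number moved a 1.0-fold higher number from compound 1 to compound 2 (0.00 log units; within the scatter). The other step, a 4.7-fold lower number from compound 2 to compound 3 (0.68 log units; beyond the scatter), swaps a group rather than a configuration and does not speak to this change. The expectation is therefore a step of no change at the digits printed from compound 3 to compound 4 (within the scatter), nothing beyond the scatter. Compound 4 is estimated at 11.8 ug/mL, with a range from 6 ug/mL to 24 ug/mL.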

Compound 4, half-maximal cytotoxic concentration: 9.2 ug/mL
The estimate for compound 4 lay 1.3-fold (0.11 log units) above the measured number; the measured number falls inside the stated range.
By their numbers in this assay, from the lowest: compounds 4 and 3 (each within the scatter of the next); then compounds 1 and 2 (each within the scatter of the next).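

With cyclohexyl in place of benzyl, the configuration at this saturated chain carbon again makes no difference beyond the scatter in this assay (a 1.3-fold lower number from compound 3 to compound 4 (0.11 log units; within the scatter)), so the flat result now holds on a second pair: the fact that compounds 3 and 4 differ only in the configuration as drawn. The second new step is a 6.0-fold lower number from compound 1 to compound 4 (0.78 log units; beyond the scatter) and shows that cyclohexyl in place of benzyl gives a similar drop on both pairs: the same change on two cores in this assay, a 4.7-fold lower number (0.68 log units; beyond the scatter) from compound 2 to compound 3 and a 6.0-fold lower number (0.78 log units; beyond the scatter) from compound 1 to compound 4, 1.3-fold (0.10 log units) apart, within the scatter of two such steps.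

Going by these compounds, whether configuration would stay this unimportant with a different group at this carbon, such as an amine or a carboxylic acid, remains open.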